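Catechol Hydroxyl on a Longer-Linked Hydrazone

This account rests on a few compounds, and the source may have more. Where it says the series, first, only, none or still open, it means among the compounds named here.

Compound 1 `O=C(CCc1nc2ccccc2c(=O)[nH]1)N/N=C/c1ccc(O)c(O)c1`, compound 2 `O=C(CCc1nc2ccccc2c(=O)[nH]1)N/N=C/c1ccc(O)cc1` and compound 3 `O=C(CCCc1nc2ccccc2c(=O)[nH]1)N/N=C/c1ccc(O)cc1` were examined in a physicochemical assay, read by spectrophotometry, with a stated time of 6 min; a higher number here means a weaker inhibitor, a lower number a stronger inhibitor. In this assay compound 1 gives 40000000 nM, compound 2 gives 105000000 nM and compound 3 gives 170000000 nM. Compound 1 differs from compound 2 by hydroxy in place of hydrogen on an aromatic carbon, a change that produced a 2.6-fold lower number from compound 2 to compound 1 (0.42 log units; beyond the scatter). Compound 2 and compound 3 share the hydrazone end but carry different cores; the difference between the two cores is not broken down here, and their two values in this assay lie within the usual scatter of each other.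

Compound 4 `O=C(CCCc1nc2ccccc2c(=O)[nH]1)N/N=C/c1ccc(O)c(O)c1` has not yet been measured. For the measured compounds named here, it differs from compound 3 by hydroxy in place of hydrogen on an aromatic carbon, which is the same change as the one from compound 2 to compound 1, made on the core of compound 3. Because a 2.6-fold lower number from compound 2 to compound 1 (0.42 log units; beyond the scatter) was seen for that change, an estimated step of a 2.6-fold lower number from compound 3 to compound 4 (0.42 log units; beyond the scatter) is expected in this assay. The value of compound 4 in this assay is therefore estimated at 65000000 nM, with an expected range from 30000000 nM to 140000000 nM.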

Compound 4, half-maximal inhibitory concentration: 50000000 nM
For compound 4 the middle estimate is 1.3-fold (0.11 log units) above the measured one, within the range that was stated.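

In this assay, hydroxy in place of hydrogen on an aromatic carbon, the change from 4-hydroxyphenyl to 3,4-dihydroxyphenyl, gave a 3.4-fold lower number from compound 3 to compound 4 (0.53 log units; beyond the scatter), in the same direction as a 2.6-fold lower number from compound 2 to compound 1 (0.42 log units; beyond the scatter), and both steps lie beyond the scatter, so the change carried over from the core of compound 2 to the core of compound 3. This rests on a single pair on each of two cores, so it shows that the direction held across these two cores, but not that it would hold on any further core or in any other kind of test. Nothing available here explains the lower number on either core.

The compounds shown leave open whether a methoxy group, a fluorine atom or a carboxylic acid in place of the entering hydroxy would lower the number in the same way. They also leave open whether the same change would give a comparable step on a core with a longer chain than that of compound 3.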